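This account rests on a few compounds, and the source may have more. Where it says the series, first, only, none or still open, it means among the compounds named here.

Compound 3 `CN(C)C(=O)c1cc2cnc(Nc3ccc(S(=O)(=O)NCCCCCN=C=S)cc3)nc2n1C1CCCC1` is one of three closely related compounds built on the shared core. In a functional assay on A549 cells (Homo sapiens) for inhibition, read by CCK-8 assay, with a stated time of 72 h, tested at 10 uM (on this read-out higher numbers stand for a stronger effect at the one concentration tested and lower numbers for a weaker effect), compound 3 gives 102%, level with compound 1 `CN(C)C(=O)c1cc2cnc(Nc3ccc(S(=O)(=O)NCCCN=C=S)cc3)nc2n1C1CCCC1`, which gives 102%, and together these two are the highest of the three numbers. Compound 2 `CN(C)C(=O)c1cc2cnc(Nc3ccc(S(=O)(=O)NCCCCN=C=S)cc3)nc2n1C1CCCC1` gives 101%; the step of a number 1 percentage points higher from compound 2 to compound 3 (within the scatter) lies within the scatter, as do a number 1 percentage points lower from compound 1 to compound 2 (within the scatter) and no change at the digits printed from compound 1 to compound 3 (within the scatter). Compound 4 `CN(C)C(=O)c1cc2cnc(Nc3ccc(C(=O)NCCCN=C=S)cc3)nc2n1C1CCCC1` differs from compound 3 in the group on the aromatic carbon: a group of 9 heavy atoms (5 carbon, 2 nitrogen, 1 oxygen, 1 sulfur; no ring) in place of a group of 12 heavy atoms (6 carbon, 2 nitrogen, 2 oxygen, 2 sulfur; no ring), on an aromatic carbon. Among the compounds with values here, all three measured steps concern only the size of the group on the saturated chain carbon, and none touches the group on the aromatic carbon, so no measured step bears directly on the change to compound 4. Since every measured compound sits near complete inhibition, compound 4 is expected to keep a high value, with a step of a number 7 percentage points lower from compound 3 to compound 4 (within the scatter) that may well stay within the scatter, though with more uncertainty than the chain changes showed. The value of compound 4 is estimated at 95%, within 70% to 105%.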

Compound 4, a percentage reported as inhibition, at one concentration (the size of the read-out at that concentration, not a potency): 103%
The estimate for compound 4 lay 8 percentage points below the measured number; the measured number falls inside the stated range.
By their numbers in this assay, from the lowest: compounds 2, 1, 3 and 4 (each within the scatter of the next).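

Within the data shown here, compound 4 is the first changed on the aromatic carbon, para to a large group, rather than along the saturated chain, with the smaller group of 9 heavy atoms replacing the sulfonamide-bearing groups. In this assay, among these compounds, this exchange stays within the scatter against each of the earlier compounds (a number 1 percentage points higher from compound 3 to compound 4 (within the scatter); a number 2 percentage points higher from compound 2 to compound 4 (within the scatter); a number 1 percentage points higher from compound 1 to compound 4 (within the scatter)). The position therefore tolerates this change at the one concentration tested, although all four numbers sit so close together that the read-out does not separate them, and nothing shown accounts for this result.

From the compounds shown here alone, it remains open whether a primary amine in place of the isothiocyanate would keep the read-out at this level. Going by these compounds, it is also open whether a longer chain on the amide of compound 4 would do so.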